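The source may report more compounds than this note shows. Statements on the series, on what has been measured and on what is new or still open speak of the compounds shown alone.

Measured so far:
- compound 1, `COc1ccc(OCC2=NCCO2)cc1`, gives 64.1% in a functional assay on the whole organism for inhibition, with Rattus norvegicus as the target, read by paw edema, with a stated time of 30 min, at a dose of 80 mg/kg by the oral route; a lower number here means a weaker effect, a higher number a stronger effect of the compound at the dose given
- compound 2, `Clc1ccc(OCC2=NCCO2)cc1`, gives 94.1% in this assay
- compound 3, `Cc1ccccc1OCC1=NCCO1`, gives 55.3% in this assay

Compound 3 has the lowest of the three numbers; its reading sits within the scatter of that of compound 1, so the two cannot be told apart, while compound 2 stands clearly higher than both. Compound 4, `O=[N+]([O-])c1ccccc1OCC1=NCCO1`, is not yet measured. It differs from compound 3 in one place: nitro in place of methyl on an aromatic carbon.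

For the measured compounds named here, only one step between measured compounds exists here, a number 30 percentage points higher from compound 1 to compound 2 (beyond the scatter), and it swaps a different group at a different place on the ring, so it bears on the present change only loosely. It shows that one ring substituent traded for another can shift the reading well beyond the scatter. With no closer guide, compound 4 is expected to give 65% in this assay, within a range of 45% to 85%. That estimate corresponds to a step of a number 9.7 percentage points higher from compound 3 to compound 4 (within the scatter), a small expected rise, with wide uncertainty on either side.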

Compound 4, a percentage reported as inhibition, in the whole organism at one dose (the size of the read-out at that dose, not a potency): 50.5%
For compound 4 the middle estimate is 14.5 percentage points above the measured one, and the stated range covers the measured number.
By their numbers in this assay, from the lowest: compounds 4, 3 and 1 (each within the scatter of the next, the first and the last beyond it); then compound 2.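

At this place on the ring, ortho to a group of 7 heavy atoms, nitro in place of methyl gives a number 4.8 percentage points lower from compound 3 to compound 4 (within the scatter) in this assay, so compound 3 and compound 4 cannot be told apart. For the compounds shown here, this is the first comparison of two groups at this one place, since the only earlier step involved other groups at a different place on the ring. Here, a single carbon gives way to a group of 3 heavy atoms with 2 hydrogen-bond acceptors, yet the reading does not separate, and no measurement on hand accounts for this.

As far as these compounds go, whether an amine, a carboxylic acid or a longer chain at this place would shift the reading beyond the scatter remains open. So does whether methyl and nitro would also read alike elsewhere on the ring.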